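Swapping the Aryl Group on a Shared Core

This account rests on a few compounds, and the source may have more. Where it says the series, first, only, none or still open, it means among the compounds named here.

Three compounds share one core and differ only in the ring sitting on a saturated chain carbon bound to a sulfur: compound 1 `COc1ccc(C2N=C(SCc3ccccc3Cl)NC(C)=C2C(=O)Nc2ccc(F)cc2)cc1OC`, compound 2 `COc1ccc(C2N=C(SCc3cccc(Cl)c3)NC(C)=C2C(=O)Nc2ccc(F)cc2)cc1OC` and compound 3 `COc1ccc(C2N=C(SCc3ccc(F)cc3)NC(C)=C2C(=O)Nc2ccc(F)cc2)cc1OC`. In a functional assay on the whole organism (artery, strain albino) with Rattus norvegicus as the target, with a stated time of 60 min, at a dose of 10 mg/kg by the oral route (on this read-out higher numbers stand for more inhibition at the one dose given (going by the name of the read-out) and lower numbers for less inhibition), compound 1 gives 11.8%, compound 2 gives 8.2% and compound 3 gives 11.8%. The number for compound 2 is the smallest of the three, yet every gap is small: a number 3.6 percentage points lower from compound 1 to compound 2 (within the scatter), a number 3.6 percentage points higher from compound 2 to compound 3 (within the scatter) and no change at the digits printed from compound 1 to compound 3 (within the scatter). Compound 4 `CC1=C(C(=O)Nc2ccc(F)cc2)C(c2ccc([N+](=O)[O-])cc2)N=C(SCc2cccc(Cl)c2)N1` arises from compound 2 by a change at a different spot: 4-nitrophenyl in place of 3,4-dimethoxyphenyl on a saturated ring carbon. For the measured compounds named here, none of the measured steps touches that spot; all of them vary the ring on the saturated chain carbon bound to a sulfur, and all stayed within the scatter, so they give no guide to the size or direction of this new change. With nothing pointing either way, compound 4 is expected to show a number 0.8 percentage points higher from compound 2 to compound 4 (within the scatter), and its estimated value is 9%, between 2% and 18%.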

Compound 4, a percentage reported as inhibition, in the whole organism at one dose (the size of the read-out at that dose, not a potency): 7.2%
The estimate for compound 4 lay 1.8 percentage points above the measured number; low and high end bracket the measured number.
By their numbers in this assay, from the lowest: compounds 4, 2, 1 and 3 (each within the scatter of the next).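

For the compounds shown here, this is the first look at the saturated ring carbon, and in this assay replacing 3,4-dimethoxyphenyl with 4-nitrophenyl there gives a number 1 percentage points lower from compound 2 to compound 4 (within the scatter). This single exchange therefore shows no difference beyond the scatter, even though two methoxy groups give way to one nitro group on the aromatic ring. No measurement is available that could account for this result.

The compounds shown leave open whether another group on the saturated ring carbon, such as a 4-aminophenyl ring, a 4-carboxyphenyl ring or a cyclohexyl ring, would move the number beyond the scatter. They also leave open whether 4-nitrophenyl and 3,4-dimethoxyphenyl would stay this close with something other than the (3-chlorobenzyl)sulfanyl group on the core.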